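Swapping the ring on the amine nitrogen: compound 4

A few compounds are considered here, and "the series" means these few. Any claim that something is new, unique, unknown or untested is made for them only; others in the source may bear on it.

Measured compounds in a functional assay on CHO cells with adenosine receptor A1 (Homo sapiens) as the target, read by cAMP accumulation and immunoassay, with a stated time of 6 min, tested at 0.01 uM; on this read-out higher numbers stand for a weaker effect at the one concentration tested and lower numbers for a stronger effect:
compound 1, `Nc1scc(CN2CCN(c3ccc(Cl)cc3F)CC2)c1C(=O)c1ccc(Cl)cc1`: -9.2%
compound 2, `Nc1scc(CN2CCN(c3ccc(Cl)c(C(F)(F)F)c3)CC2)c1C(=O)c1ccc(Cl)cc1`: -2.5%
compound 3, `Nc1scc(CN2CCN(c3cccnc3)CC2)c1C(=O)c1ccc(Cl)cc1`: 3.2%

Among these three, compound 3 has the highest number in this assay. One step is a number 12.4 percentage points higher from compound 1 to compound 3 (beyond the scatter), another is a number 5.7 percentage points higher from compound 2 to compound 3 (within the scatter), and the remaining one is a number 6.7 percentage points higher from compound 1 to compound 2 (within the scatter). So the numbers are grouped closely, with only one gap beyond the scatter.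

Compound 4, `Nc1scc(CN2CCN(C3CCCCCC3)CC2)c1C(=O)c1ccc(Cl)cc1`, is the unmeasured member. The change from compound 3 is cycloheptyl in place of pyridin-3-yl on an amine nitrogen in a ring. For the measured compounds named here, every measured step replaces one aromatic ring with another aromatic ring on that nitrogen, and none introduces a non-aromatic ring, so no step speaks directly to this change. The measured steps were small, and the account therefore expects no step beyond the scatter in this assay for compound 4.

Compound 4 is expected to give 2% in this assay, within a range from -10% to 14%, a step from compound 3 of a number 1.2 percentage points lower from compound 3 to compound 4 (within the scatter) that is estimated, not measured.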

Compound 4, a percentage reported as activity, at one concentration (the size of the read-out at that concentration, not a potency): 2.9%
Beside the measured number, compound 4's estimate is 0.9 percentage points below it; the range from low to high includes it.
By their numbers in this assay, from the lowest: compounds 1, 2, 4 and 3 (each within the scatter of the next, the first and the last beyond it).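

Compound 4 puts a non-aromatic ring on this amine nitrogen for the first time among the compounds shown, and this assay gives a number 0.3 percentage points lower from compound 3 to compound 4 (within the scatter) as the step from pyridin-3-yl, so an aromatic ring is not required here for a reading in this range. Cycloheptyl also stands where pyridin-3-yl stood against the two halogenated phenyl groups, with a number 5.4 percentage points higher from compound 2 to compound 4 (within the scatter) and with a number 12.1 percentage points higher from compound 1 to compound 4 (beyond the scatter) in this assay on this read-out. Nothing available explains why these different rings read alike.

On these data alone, whether a hexyl chain or a group carrying a carboxylic acid on this nitrogen would stay in the same range remains open. Readings at one concentration also leave the potency of all these compounds undefined.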